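Exchanging the Chlorofuran Ring for a Methylphenyl Group

A few compounds are considered here, and "the series" means these few. Any claim that something is new, unique, unknown or untested is made for them only; others in the source may bear on it.

Measured compounds:
Compound 1, `N#C/C(=C\c1ccc[nH]1)C(=O)NCc1ccc(Cl)c(Cl)c1`, gives in a functional assay on MIA cells (Homo sapiens) for inhibition, read by MTT assay, with a stated time of 72 h (a higher number here means a weaker inhibitor of growth, a lower number a stronger inhibitor of growth), a value of > 50000 nM, which is a limit of the assay.
Compound 2, `COc1ccc(CNC(=O)/C(C#N)=C/c2ccc(Cl)o2)cc1`, gives in this assay a value of 15000 nM.
Compound 3, `COc1ccc(CNC(=O)/C(C#N)=C/c2ccc(-c3ccccc3)o2)cc1`, gives in this assay a value of > 100000 nM, which is a limit of the assay.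

Going by the values given here, compound 2 therefore stands as the only compound with a number in this assay; the other two compounds sit at limits. The value of compound 1 is a limit (the limit of > 50000 nM in this assay, at which 1 of the 3 values shown sits). The value of compound 3 is a limit (the limit of > 100000 nM in this assay, at which 1 of the 3 values shown sits). Among the compounds with values here, the single measured step is an at least 6.6-fold higher number from compound 2 to compound 3 (0.82 log units; beyond the scatter), a change on the five-membered ring that weakened growth inhibition.

Compound 4, `COc1ccc(CNC(=O)/C(C#N)=C/c2ccc(C)cc2)cc1`, differs from compound 2 by 4-methylphenyl in place of 5-chlorofuran-2-yl on a double-bonded chain carbon bound to a double-bonded chain carbon. Within the data shown here, no measured step covers exchanging the ring itself, so the one step that exists bears only loosely on this change. Among the measured compounds shown here, since the only change seen on this ring weakened the inhibitor, a weaker result is expected rather than a stronger one. Compound 4 is expected in this assay at about 30000 nM, with a range from 8000 nM to 100000 nM. That estimate would mean an expected step of a 2.0-fold higher number from compound 2 to compound 4 (0.30 log units; within the scatter).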

Compound 4, concentration for 50% growth inhibition: 38000 nM
Beside the measured number, compound 4's estimate is 1.3-fold (0.10 log units) below it; the measured number falls inside the stated range.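

In this assay, the ring on the double-bonded chain carbon can be exchanged outright and growth inhibition still reads as a number: 4-methylphenyl in place of 5-chlorofuran-2-yl gives a 2.5-fold higher number from compound 2 to compound 4 (0.40 log units; beyond the scatter), a modest loss. Compound 3, which keeps the furan and changes only its substituent, sits at a limit of the assay, > 100000 nM. Nothing shown gives a reason for the step to compound 4.

The step changes the ring and its substituent together, so the compounds shown do not tell how much of the loss belongs to either one. A 4-chlorophenyl group would keep the chlorine on a six-membered ring, and a 5-methylfuran-2-yl group would keep the methyl on the furan, each separating the two changes.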